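The source may report more compounds than this note shows. Statements on the series, on what has been measured and on what is new or still open speak of the compounds shown alone.

The measured compounds and their results in a functional assay on HepG2 cells (Homo sapiens) for cytotoxicity, read by sulforhodamine B assay, with a stated time of 48 h; on this read-out lower numbers stand for stronger inhibition and higher numbers for weaker inhibition:

compound 1, `COc1ccc(/C=C/C(=O)c2cccc(-c3cccc(F)c3)c2)cc1`, gives 1720 nM
compound 2, `COc1ccc(/C=C/C(=O)c2cccc(-c3cccc(F)c3)c2)cc1OC`, gives 1170 nM
compound 3, `COc1ccc(/C=C/C(=O)c2cccc(-c3cccc(F)c3)c2)cc1O`, gives "not determined" (no result reported)

Among the compounds with values here, compound 1 stands with the highest of the two numbers recorded; its nearest neighbour is compound 2, and the single measured step, a 1.5-fold lower number from compound 1 to compound 2 (0.17 log units; within the scatter), amounts to methoxy in place of hydrogen on an aromatic carbon and lies within the scatter. Compound 3 contributes no number and so sets no reference.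

The unmeasured compound 4, `O=C(/C=C/c1cccc(Br)c1)c1cccc(-c2cccc(F)c2)c1`, differs from compound 1 as follows: 3-bromophenyl in place of 4-methoxyphenyl on a double-bonded chain carbon bound to a double-bonded chain carbon. Within the data shown here, this change concerns a different part of the shared core from the one altered between compound 1 and compound 2, so no measured step speaks directly to it. Among the measured compounds shown here, the only step available, a 1.5-fold lower number from compound 1 to compound 2 (0.17 log units; within the scatter), is small, and the data give no ground for expecting a move beyond the scatter in this assay in either direction. The expected step is therefore a 1.0-fold lower number from compound 1 to compound 4 (0.01 log units; within the scatter), that is, essentially none. Compound 4 is estimated at 1700 nM in this assay, with a range from 700 nM to 4500 nM, the width reflecting how little the measured compounds say about this change.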

Compound 4, half-maximal inhibitory concentration: 6980 nM
Beside the measured number, compound 4's estimate is 4.1-fold (0.61 log units) below it; the whole stated range lies below it.
By their numbers in this assay, from the lowest: compounds 2 and 1 (each within the scatter of the next); then compound 4.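

In this assay, within the data shown here, 3-bromophenyl in place of 4-methoxyphenyl on a double-bonded chain carbon bound to a double-bonded chain carbon gives a 4.1-fold higher number from compound 1 to compound 4 (0.61 log units; beyond the scatter) and so provides the first step here beyond the scatter, whereas the earlier change gave only a 1.5-fold lower number from compound 1 to compound 2 (0.17 log units; within the scatter) and left open whether any change to these compounds would register in this read-out. Among these compounds, the result shows that this position can respond, with the change here going towards weaker inhibition, but the single exchange removes the methoxy group and its hydrogen-bond acceptor and brings in bromine on the ring at once, so the step cannot be divided among those parts. The data offer nothing that explains the step.

As far as these compounds go, whether plain phenyl, 4-bromophenyl, or a ring carrying an amine or a carboxylic acid at this place would give a number closer to that of compound 1 or further from it remains open. Also open, from the compounds shown here alone, is whether the step would keep its size if the fluorophenyl group shared by these compounds were replaced by another group.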